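Cytotoxicity notes: fluoro to hydrogen on compound 1

The source may report more compounds than this note shows. Statements on the series, on what has been measured and on what is new or still open speak of the compounds shown alone.

Measured compounds in an ADME assay on MT4 cells (Homo sapiens) for cytotoxicity; on this read-out higher numbers stand for lower toxicity in this test and lower numbers for higher toxicity in this test:
compound 1, `Fc1ccccc1NC(=S)Nc1cccc(C(F)(F)F)c1`: 47000 nM
compound 2, `C=C(C)CNC(=S)Nc1cccc(C(F)(F)F)c1`: 43000 nM
compound 3, `CC(=O)NC(=S)Nc1cccc(C(F)(F)F)c1`: a limit, > 100000 nM

Among the two numbers in this assay compound 1 gives the higher one, and compound 2 lies within the scatter of it, as a 1.1-fold lower number from compound 1 to compound 2 (0.04 log units; within the scatter) shows. Compound 3 reports only a limit, (the limit of > 100000 nM in this assay, at which 1 of the 3 values shown sits). Compound 4, `FC(F)(F)c1cccc(NC(=S)Nc2ccccc2)c1`, is not yet measured; it differs from compound 1 by hydrogen in place of fluoro on an aromatic carbon.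

Going by the values given here, no measured step touches this position. Both measured steps from compound 1 replace the whole group on the amide-type nitrogen: a 1.1-fold lower number from compound 1 to compound 2 (0.04 log units; within the scatter) stays within the scatter, while an at least 2.1-fold higher number from compound 1 to compound 3 (0.32 log units; beyond the scatter) runs up to the limit. The change to compound 4 is smaller than either, a single fluorine leaving the ring, so no step beyond the scatter is expected in this assay. The expected step is a 1.1-fold higher number from compound 1 to compound 4 (0.03 log units; within the scatter). Compound 4 is therefore estimated at 50000 nM, with a range from 25000 nM to 100000 nM.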

Compound 4, half-maximal cytotoxic concentration: 39000 nM
The estimate for compound 4 lay 1.3-fold (0.11 log units) above the measured number; measured number inside the range.
By their numbers in this assay, from the lowest: compounds 4, 2 and 1 (each within the scatter of the next). At a limit, above all of these: compound 3.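

In this assay the step at this aromatic carbon can now be read, and 2-fluorophenyl and phenyl on the amide-type nitrogen are not told apart (a 1.2-fold lower number from compound 1 to compound 4 (0.08 log units; within the scatter)), nor are phenyl and 2-methylprop-2-en-1-yl (a 1.1-fold lower number from compound 2 to compound 4 (0.04 log units; within the scatter)). Among the groups shown on that nitrogen, only acetyl stands apart, now also against phenyl (an at least 2.5-fold lower number from compound 3 to compound 4 (0.40 log units; beyond the scatter)). Compound 3 gives a limit, not a number: the limit of > 100000 nM in this assay, at which 1 of the 4 values shown sits.

The compounds shown leave open whether a methoxy group or an amine at this aromatic carbon would give a step beyond the scatter. They also leave open whether a carboxylic acid or a longer chain on the amide-type nitrogen would stand with acetyl or with the other groups on this read-out.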